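Ester in place of piperazinyl amide on a shared core

The source may hold more compounds than are shown below. What is called first, only, known or untested is meant among the compounds shown, and "the series" means these compounds.

Measured so far in an assay on isolated protein for inhibition of MAP kinase-interacting serine/threonine-protein kinase 1 (Homo sapiens), read by HTRF, in the presence of a further agent that is not named here; a lower number here means a stronger inhibitor, a higher number a weaker inhibitor:
Compound 1, `CCCNC(=O)c1cccc(C#Cc2ccccc2Nc2ncnc3ccc(Cl)nc23)c1`: > 10000 nM, a limit of the assay rather than a number.
Compound 2, `O=C(c1cccc(C#Cc2ccccc2Nc2ncnc3ccc(Cl)nc23)c1)N1CCNCC1`: > 10000 nM, likewise a limit.

Compound 2 therefore stands at the edge of what this assay can read: the value is only a limit, and the limit of > 10000 nM in this assay, at which 2 of the 2 values shown sit, is all the evidence there is. Among the measured compounds shown here, the one measured step, a step that the two limits leave unreadable from compound 1 to compound 2, cannot be sized, since both ends of it are limits.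

Compound 3, `COC(=O)c1cccc(C#Cc2ccccc2Nc2ncnc3ccc(Cl)nc23)c1`, differs from compound 2 by methoxy in place of piperazin-1-yl on a carbonyl carbon. For the measured compounds named here, no measured step bears on this change in a readable way; the only guide is that both known compounds, whatever their amide, sit at the limit. The expectation is thus that compound 3 shows no step beyond the scatter in this assay and most likely again reaches only the limit. Compound 3 is estimated at 15000 nM, with a range from 3000 nM to 60000 nM. This estimate implies a step that the limit leaves unreadable from compound 2 to compound 3, expected to be unreadable in practice.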

Compound 3, half-maximal inhibitory concentration: > 10000 nM
Compound 3: only a limit was reported; the forecaster's own chance of this, stated with the estimate: 85%; the middle value does not contradict the limit.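

Compound 3, like compound 1 and compound 2, gives only a limit in this assay, so no step among these three compounds can be read: the limit of > 10000 nM in this assay, at which 3 of the 3 values shown sit.

The compounds shown leave open whether any group on the carbonyl carbon of the shared core would give a readable value in this assay, and how large that value would be.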